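Swapping Acetyl for Chloro on a Glioblastoma Cell Screen

The source may hold more compounds than are shown below. What is called first, only, known or untested is meant among the compounds shown, and "the series" means these compounds.

Three compounds built on one shared core were tested in a functional assay on SNB-19 cells (Homo sapiens) for inhibition, read by sulforhodamine B assay, with a stated time of 48 h, tested at 10 uM; on this read-out lower numbers stand for less inhibition and higher numbers for more inhibition at the one concentration tested (going by the name of the read-out). Compound 1 `Brc1cn2ccnc2c(-c2ccc3ncn(C4CCCCC4)c3c2)n1` gives 8.09%. Compound 2 `c1cn2cc(-c3ccsc3)nc(-c3ccc4ncn(C5CCCCC5)c4c3)c2n1` gives 0.39%. Compound 3 `CC(=O)c1ccc(-c2cn3ccnc3c(-c3ccc4ncn(C5CCCCC5)c4c3)n2)cc1` gives 3.96%. Compound 3 stands second highest of the three numbers, but its steps to the other two, a number 4.1 percentage points lower from compound 1 to compound 3 (within the scatter) and a number 3.6 percentage points higher from compound 2 to compound 3 (within the scatter), both lie within the scatter, so no real order among the three can be read from these figures.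

Compound 4 `Clc1ccc(-c2cn3ccnc3c(-c3ccc4ncn(C5CCCCC5)c4c3)n2)cc1` differs from compound 3 in a single place: chloro in place of acetyl on an aromatic carbon. The change sits on a six-membered aromatic ring of carbon only, para to a large group. The measured steps that bear on it are those that exchanged the group at this same end of the molecule: a number 7.7 percentage points lower from compound 1 to compound 2 (within the scatter), a number 4.1 percentage points lower from compound 1 to compound 3 (within the scatter) and a number 3.6 percentage points higher from compound 2 to compound 3 (within the scatter). Every one of them stayed within the scatter, so replacing bromo by thiophen-3-yl or by 4-acetylphenyl made no difference that this assay could resolve. On that basis, trading acetyl for chloro is expected to leave the number close to the others, a step of a number 0 percentage points higher from compound 3 to compound 4 (within the scatter). Compound 4 is therefore estimated to give about 4%, most likely between -6% and 14%.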

Compound 4, a percentage reported as inhibition, at one concentration (the size of the read-out at that concentration, not a potency): 15.8%
Estimate against measurement, compound 4: 11.8 percentage points below; the measured number lies above the stated range.
By their numbers in this assay, from the lowest: compounds 2, 3, 1 and 4 (each within the scatter of the next, the first and the last beyond it).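

Chloro in place of acetyl is the first exchange at this end of the molecule that this assay can resolve (in this step, a number 11.8 percentage points higher from compound 3 to compound 4 (beyond the scatter)), and the comparison with thiophen-3-yl also clears the scatter (a number 15.4 percentage points higher from compound 2 to compound 4 (beyond the scatter)), although both steps are modest. So the group on this six-membered aromatic ring can shift the reading, which the earlier compounds, all within the scatter of one another, could not show, yet 4-chlorophenyl remains unresolved from the plain bromo of the shared core (a number 7.7 percentage points higher from compound 1 to compound 4 (within the scatter)). Nothing available here explains why chloro and acetyl part at this position.

The compounds shown leave open whether the gain belongs to chloro itself or simply to the loss of acetyl, and whether an amine, a carboxylic acid or a methoxy group on the same aromatic carbon would follow chloro or acetyl. Each figure is also a single reading at one concentration, so how potent any of these compounds is remains unknown.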